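Methoxy in place of hydrogen on compound 2

The source may hold more compounds than are shown below. What is called first, only, known or untested is meant among the compounds shown, and "the series" means these compounds.

In an ADME assay on MT4 cells (Homo sapiens) for cytotoxicity, read by MTT assay, with a stated time of 96 h (a lower number here means that less compound is tolerated, a higher number that more compound is tolerated), compound 2 `COc1ccc(-c2nc3cc(/C(C)=N/O)ccc3[nH]2)c(OC)c1` gives only a limit, >= 100000 nM, and no number.

For the measured compounds named here, the only numeric reading so far belongs to compound 1 `COc1ccc(-c2nc3cc(C(C)O)ccc3[nH]2)c(OC)c1OC`, at 79000 nM. Compound 1 differs from compound 2 in more than one place, so the two results do not isolate the effect of any single structural change.

Compound 3 `COc1ccc(-c2nc3cc(/C(C)=N/O)ccc3[nH]2)c(OC)c1OC` keeps the oxime side of compound 2 and carries methoxy in place of hydrogen on an aromatic carbon. Going by the values given here, no measured pair shows this change on its own, so the expectation rests on indirect evidence.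

Compound 1 already has a methoxy group in that place and gives 79000 nM in this assay, which points to little tolerance being lost with this substitution. The expected step of an at least 1.1-fold lower number from compound 2 to compound 3 (0.07 log units; that floor lies within the scatter) is small and downward, possibly no larger than the scatter. A further report of only a limit would not be surprising.

For compound 3 the estimate is 85000 nM, with an expected range of 40000 nM to 100000 nM.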

Compound 3, half-maximal cytotoxic concentration: 51000 nM
The estimate for compound 3 lay 1.7-fold (0.22 log units) above the measured number; measured number inside the range.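

In this assay, methoxy in place of hydrogen on an aromatic carbon, ortho to two methoxy groups, now has a reading as a single change: an at least 1.9-fold lower number from compound 2 to compound 3 (0.29 log units; that floor lies within the scatter). As far as these compounds go, compound 2 gives only a limit, so this step is a floor and its full size stays unknown: the limit of >= 100000 nM in this assay, at which 1 of the 3 values shown sits. With the methoxy held in place and only the side group changed, the series gives a 1.5-fold lower number from compound 1 to compound 3 (0.19 log units; within the scatter), so the oxime side of compound 3 and the side group of compound 1 cannot be told apart in this assay.

From the compounds shown here alone, whether the step from hydrogen to methoxy at this carbon goes beyond the scatter remains open, and so does whether it would look the same with the side group of compound 1 in place of the oxime. Also open is how this assay would respond at this same carbon to an amine, a carboxylic acid or a longer chain such as propoxy, since methoxy and hydrogen are the only groups shown there.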